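Shortening the Ester Arm from Compound 3 to Compound 4

A few compounds are considered here, and "the series" means these few. Any claim that something is new, unique, unknown or untested is made for them only; others in the source may bear on it.

Compound 1 `CCCCCCOc1ccc2c(=O)c(-c3ccc(O)cc3)coc2c1` gives 1500 nM in an assay (Cricetulus griseus) for inhibition of aldehyde dehydrogenase, mitochondrial (Homo sapiens); on this read-out higher numbers stand for weaker inhibition and lower numbers for stronger inhibition.
Compound 2 `O=C(O)CCCCCCCCCCCCCCCOc1ccc2c(=O)c(-c3ccc(O)cc3)coc2c1` reaches only a limit in this assay, > 9000 nM.
Compound 3 `CCOC(=O)CCCCCOc1ccc2c(=O)c(-c3ccc(O)cc3)coc2c1` gives 280 nM in this assay.

Among the measured compounds shown here, compound 3 holds the lowest of the two numbers, with compound 1 nearest; the move between them, a 5.4-fold lower number from compound 1 to compound 3 (0.73 log units; beyond the scatter), is the only measured step that lowers the number. The other measured step, an at least 6.0-fold higher number from compound 1 to compound 2 (0.77 log units; beyond the scatter), runs toward weaker inhibition and ends at the limit described as the limit of > 9000 nM in this assay, at which 1 of the 3 values shown sits.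

Compound 4 `CCOC(=O)CCCCOc1ccc2c(=O)c(-c3ccc(O)cc3)coc2c1` is the next step from compound 3. The change is ethoxycarbonyl in place of (ethoxycarbonyl)methyl on a saturated chain carbon, four bonds along the chain from an oxygen on an aromatic ring. Neither measured step resembles this one: both of them swap or add a group at the end of the chain, while here the chain is cut shorter by one carbon with the ester kept. The measured steps therefore give no direct guide, and the small size of the change suggests a step that stays within, or just at the edge of, the scatter. The number for compound 4 is expected to sit close to that of compound 3, and the expected step is a 1.4-fold higher number from compound 3 to compound 4 (0.15 log units; within the scatter). Compound 4 is estimated at 400 nM, with a range from 150 nM to 1200 nM.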

Compound 4, half-maximal inhibitory concentration: 240 nM
Compound 4: middle estimate off by 1.7-fold (0.22 log units), on the high side, within the range that was stated.
By their numbers in this assay, from the lowest: compounds 4 and 3 (each within the scatter of the next); then compound 1. At a limit, above all of these: compound 2.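

Within the ester series, ethoxycarbonyl in place of (ethoxycarbonyl)methyl makes no difference that can be read in this assay: a 1.2-fold lower number from compound 3 to compound 4 (0.07 log units; within the scatter). Set against compound 1, the second ester gives a 6.3-fold lower number from compound 1 to compound 4 (0.80 log units; beyond the scatter), so the lower number seen with compound 3 is not confined to a single ester chain length and now holds for both esters shown. Nothing measured here explains what in the ester or the chain lies behind these numbers.

The compounds shown leave open how much shorter the chain can become with the ester kept, as in 3-(ethoxycarbonyl)propyl or 2-(ethoxycarbonyl)ethyl, and whether an amide or an amine at the chain end would hold the number near those of compound 3 and compound 4. From the compounds shown here alone, the only carboxylic acid shown sits on a much longer chain in compound 2, whose > 9000 nM is a limit, so the effect of a carboxylic acid at the end of a short chain also remains open.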